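The compounds below may be only part of what the source reports. "The series", "measured", "known", "first", "only" and "open" are said of these compounds alone.

Measured compounds in an assay on brain for displacement of a labelled ligand from metabotropic glutamate receptor 5 (Rattus norvegicus); on this read-out higher numbers stand for weaker inhibition and lower numbers for stronger inhibition:
- compound 1 `COc1cccc(C#Cc2csc(Cl)n2)c1` gives 8.1 nM
- compound 2 `COc1cccc(C#Cc2csc(F)n2)c1` gives 22.7 nM
- compound 3 `Cc1nc(C#Cc2cc(F)cc(C#N)c2)cs1` gives 0.08 nM

Compound 3 stands at the lowest number of the three; compound 1 is nearest and compound 2 is furthest, both gaps well beyond the scatter. Compound 3 is thus the strongest inhibitor among the measured set.

Compound 4 `N#Cc1cc(F)cc(C#Cc2csc(Br)n2)c1` differs from compound 3 in one place: bromo in place of methyl on an aromatic carbon. Within the data shown here, the only measured step touches the same ring carbon, a 2.8-fold higher number from compound 1 to compound 2 (0.45 log units; beyond the scatter), where one halogen replaced another. Among the measured compounds shown here, no measured step covers the exchange of methyl for a halogen, so the direct precedent is lacking. For the measured compounds named here, the one step that exists was modest and nudged the number upward on going to the smaller halogen; a larger halogen entering in place of methyl is expected to leave the number near where compound 3 stands, with a small rise more likely than a fall. The expected step in this assay is a 1.9-fold higher number from compound 3 to compound 4 (0.27 log units; within the scatter). For compound 4 the estimate in this assay is 0.15 nM, with a range from 0.04 nM to 0.6 nM.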

Compound 4, inhibition constant: 0.95 nM
Compound 4: middle estimate off by 6.3-fold (0.80 log units), on the low side; measured number above the stated range.
By their numbers in this assay, from the lowest: compound 3; then compound 4; then compound 1; then compound 2.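

In this assay, bromo in place of methyl on the aromatic carbon next to the ring nitrogen and next to the ring sulfur gives a 12-fold higher number from compound 3 to compound 4 (1.07 log units; beyond the scatter), a large step, so this position is sensitive to the exchange of a single heavy atom. Among these compounds, the earlier step at this carbon, a 2.8-fold higher number from compound 1 to compound 2 (0.45 log units; beyond the scatter), was a modest one between two halogens on the core of compound 1; the new pair is the first to set a halogen against methyl, and on this core methyl gives the lower number. The exchange leaves the heavy-atom count, donors, acceptors and net charge unchanged, and nothing measured here accounts for the rise.

The compounds shown leave open whether chloro and fluoro would keep their order on the core of compound 3, as the only pair comparing them sits on the core of compound 1. They also leave open how an ethyl group, an amine or a methoxy group at this carbon would compare with methyl, and so whether methyl is a narrow optimum at this position.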